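Notes on the aryl substituent step to compound 4

The compounds below may be only part of what the source reports. "The series", "measured", "known", "first", "only" and "open" are said of these compounds alone.

Going by the values given here, in an assay on isolated protein for displacement of a labelled ligand from melanin-concentrating hormone receptor 1 (Homo sapiens) (on this read-out higher numbers stand for weaker inhibition and lower numbers for stronger inhibition), compound 3 `CCCc1cc(N)c2cc(NC(=O)/C=C/c3ccc(F)cc3)ccc2n1` gives 130 nM, the second highest of the three numbers so far. Compound 1 `CCCc1cc(N)c2cc(NC(=O)/C=C/c3ccc(O)cc3)ccc2n1` gives 1100 nM and compound 2 `CCCc1cc(N)c2cc(NC(=O)/C=C/c3ccc(Cl)cc3Cl)ccc2n1` gives 6.6 nM. Compound 4 `CCCc1cc(N)c2cc(NC(=O)/C=C/c3ccc(CC)cc3)ccc2n1` differs from compound 3 by ethyl in place of fluoro on an aromatic carbon. Among the compounds with values here, two measured steps bear on this aromatic carbon: an 8.5-fold lower number from compound 1 to compound 3 (0.93 log units; beyond the scatter) and a 20-fold higher number from compound 2 to compound 3 (1.29 log units; beyond the scatter), though the latter step changes more than one group. Both show that the group at this position moves the number well beyond the scatter, and that leaving hydroxy for halogen lowers it. Ethyl is expected to continue this modestly, so the step of a 2.6-fold lower number from compound 3 to compound 4 (0.41 log units; beyond the scatter) is estimated. Compound 4 is therefore expected to give 50 nM, within 15 nM to 160 nM.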

Compound 4, half-maximal inhibitory concentration: 1.4 nM
Estimate against measurement, compound 4: 36-fold (1.55 log units) above; the measured number lies below the stated range.
By their numbers in this assay, from the lowest: compound 4; then compound 2; then compound 3; then compound 1.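

In this assay, going by these compounds alone, ethyl on this aromatic carbon gives a 93-fold lower number from compound 3 to compound 4 (1.97 log units; beyond the scatter) and a 790-fold lower number from compound 1 to compound 4 (2.90 log units; beyond the scatter), so among the single groups here the numbers fall from hydroxy through fluoro to ethyl. The halogen pattern of compound 2 no longer marks the low end of the series: 4-ethylphenyl gives a 4.7-fold lower number from compound 2 to compound 4 (0.67 log units; beyond the scatter), although that step changes more than one group. No available evidence explains the difference between ethyl and fluoro. Open, as far as these compounds go, is whether a longer chain such as butyl, or branched isopropyl, lowers the number further or reverses the trend. Also open, from the compounds shown here alone, is whether adding a chloro group to 4-ethylphenyl lowers it further.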